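Varying the group on the aromatic nitrogen

The source may hold more compounds than are shown below. What is called first, only, known or untested is meant among the compounds shown, and "the series" means these compounds.

Three compounds of the series have numbers in an assay on Prostate gland for inhibition of steroid 5-alpha-reductase (Rattus norvegicus); on this read-out higher numbers stand for weaker inhibition and lower numbers for stronger inhibition. Compound 1 `CCCCCCCn1ccc2cc(/C(C)=C/C(=O)Nc3ccccc3OCCCC(=O)O)ccc21` gives 120 nM, the highest of the three numbers. Compound 2 `CCC(C)n1ccc2cc(/C(C)=C/C(=O)Nc3ccccc3OCCCC(=O)O)ccc21` gives 67 nM, and compound 3 `CCCCCC(CCCCC)n1ccc2cc(/C(C)=C/C(=O)Nc3ccccc3OCCCC(=O)O)ccc21` gives 25 nM. The change a 1.8-fold lower number from compound 1 to compound 2 (0.25 log units; within the scatter) lies within the scatter, whereas a 4.8-fold lower number from compound 1 to compound 3 (0.68 log units; beyond the scatter) and a 2.7-fold lower number from compound 2 to compound 3 (0.43 log units; beyond the scatter) are modest steps beyond it; the only movement beyond the scatter so far comes with the 1-pentylhexyl group on the aromatic nitrogen.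

Compound 4 `C/C(=C\C(=O)Nc1ccccc1OCCCC(=O)O)c1ccc2c(ccn2Cc2cccc(C)c2)c1` is not yet measured. Relative to compound 1 the change is 3-methylphenyl in place of hexyl on a saturated chain carbon bound to an aromatic nitrogen. For the measured compounds named here, none of the measured steps swaps a chain for an aromatic ring at this place, so they bear on it only loosely: they show that altering the group on the aromatic nitrogen moves the number by a modest amount at most, and never upward from compound 1. Compound 4 is therefore expected to give 60 nM, with a range of 20 nM to 180 nM. The step this estimate means, a 2.0-fold lower number from compound 1 to compound 4 (0.30 log units; within the scatter), is expected to be small and downward, possibly within the scatter.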

Compound 4, half-maximal inhibitory concentration: 250 nM
Compound 4: the middle estimate sits 4.2-fold (0.62 log units) below what was measured; measured number outside the range, above it.
By their numbers in this assay, from the lowest: compound 3; then compounds 2 and 1 (each within the scatter of the next); then compound 4.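

The group on the aromatic nitrogen can also raise the number in this assay: 3-methylbenzyl in place of heptyl gives the first rise from compound 1 in the series (a 2.1-fold higher number from compound 1 to compound 4 (0.32 log units; beyond the scatter)). The gap widens against the branched groups (a 3.7-fold higher number from compound 2 to compound 4 (0.57 log units; beyond the scatter); a 10-fold higher number from compound 3 to compound 4 (1.00 log units; beyond the scatter)), which makes compound 4 the weakest inhibitor of the four and places this one ring-bearing group behind all three chains. Nothing at hand explains why the ring-bearing group falls behind the chains.

With a single ring-bearing group in view, the rise cannot yet be assigned to the aromatic ring itself or to the methyl on it. Plain benzyl and cyclohexylmethyl on the aromatic nitrogen would separate these two readings.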